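This account rests on a few compounds, and the source may have more. Where it says the series, first, only, none or still open, it means among the compounds named here.

Measured so far in an assay on striatum for inhibition of 5-hydroxytryptamine receptor 4 (Cavia porcellus), read by radioligand binding; on this read-out lower numbers stand for stronger inhibition and higher numbers for weaker inhibition:
- compound 1 `COc1cc(N)c(Cl)cc1C(=O)NC1CCN(CC2CCN(C(=O)C(C)(C)N)CC2)CC1` gives 2.6 nM
- compound 2 `COc1cc(N)c(Cl)cc1C(=O)NC1CCN(C(=O)C2CCN(C(=O)CCCN)CC2)CC1` gives 425 nM
- compound 3 `COc1cc(N)c(Cl)cc1C(=O)NCC(O)CN1CCC(CN2CCC(N)CC2)CC1` gives 40.6 nM

Compound 1 stands at the lowest number of the three; compound 3 is nearest to it and compound 2 furthest, both gaps beyond the scatter. No two of these compounds differ in only one place, so no single step can be read from them.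

Compound 4 `COc1cc(N)c(Cl)cc1C(=O)NC1CCN(CC2CCN(CC(C)CN)CC2)CC1` has not yet been run in this assay. It differs from compound 1 as follows: 2-(aminomethyl)propyl in place of (1-amino-1-methylethyl)carbonyl on an amine nitrogen in a ring

Among the compounds with values here, with no comparable step among the measured compounds, the expectation for compound 4 rests on compound 1 alone, taking the measured value 2.6 nM as anchor. The step of a 1.9-fold higher number from compound 1 to compound 4 (0.28 log units; within the scatter) is expected to be small, at most modestly toward a higher number. Compound 4 is accordingly estimated at 5 nM, within 1.5 nM to 18 nM.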

Compound 4, half-maximal inhibitory concentration: 14.3 nM
The estimate for compound 4 lay 2.9-fold (0.46 log units) below the measured number, and the stated range covers the measured number.
By their numbers in this assay, from the lowest: compound 1; then compound 4; then compound 3; then compound 2.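

In this assay, within the data shown here, a 5.5-fold higher number from compound 1 to compound 4 (0.74 log units; beyond the scatter) gives the first readable step at this amine nitrogen of the six-membered ring, and it lies beyond the scatter. The carbonyl is thus not needed for a low number at this position: compound 4 still gives 14.3 nM. No measurement on hand bears on the reason for this rise.

On these data alone, the swap changes the carbonyl and the branching together, so their separate contributions stay open. A straight aminobutyl chain on the same nitrogen would address the branching alone.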